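Alkylating the Aniline Nitrogen of a Styryl Sulfone

The source may hold more compounds than are shown below. What is called first, only, known or untested is meant among the compounds shown, and "the series" means these compounds.

Compound 1, `COc1cc(OC)c(/C=C/S(=O)(=O)Cc2ccc(F)c(N)c2)c(OC)c1`: 2500 nM
Compound 2, `COc1cc(OC)c(/C=C/S(=O)(=O)Cc2ccc(OC)c(N)c2)c(OC)c1`: 2.5 nM

Going by the values given here, in a functional assay on K562 cells (Homo sapiens) for cytotoxicity, read by trypan blue exclusion, with a stated time of 96 h (on this read-out higher numbers stand for weaker inhibition and lower numbers for stronger inhibition), compound 2 gives 2.5 nM, the lowest of the two numbers measured so far. Among the compounds with values here, its only neighbour is compound 1, and the gap between them is large: a 1000-fold lower number from compound 1 to compound 2 (3.00 log units; beyond the scatter). That step, however, concerns a methoxy in place of fluoro on an aromatic carbon, a different part of the molecule from the one now in question.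

Compound 3, `COC(=O)[C@H](C)Nc1cc(CS(=O)(=O)/C=C/c2c(OC)cc(OC)cc2OC)ccc1OC`, has not yet been measured. It differs from compound 2 in one place: 1-(methoxycarbonyl)ethyl in place of hydrogen on a nitrogen on an aromatic ring. Within the data shown here, no measured step touches this nitrogen, so there is nothing in the data that points clearly to a stronger or weaker outcome. Substituents of this kind often leave potency roughly where it was or cost a little, and the estimate below leans slightly toward the weaker side while allowing a wide range. Compound 3 is expected to give 10 nM, between 2 nM and 60 nM. For compound 3 this amounts to an expected 4.0-fold higher number from compound 2 to compound 3 (0.60 log units; beyond the scatter).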

Compound 3, half-maximal inhibitory concentration: 200 nM
Beside the measured number, compound 3's estimate is 20-fold (1.30 log units) below it, and the stated range ends below it.
By their numbers in this assay, from the lowest: compound 2; then compound 3; then compound 1.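

In this assay the nitrogen on the aromatic ring proves sensitive to what it carries: putting 1-(methoxycarbonyl)ethyl in place of its hydrogen gives an 80-fold higher number from compound 2 to compound 3 (1.90 log units; beyond the scatter), so this nitrogen is not a spot where a substituent passes without consequence. The step is large and beyond the scatter, yet compound 3 still gives 200 nM and so keeps a measurable value in this assay, which means that this substituent weakens inhibition without abolishing it. Nothing measured here bears on why the number rises at this nitrogen.

With only one substituent on this nitrogen, the step cannot be divided among the parts of the added group: the methoxycarbonyl ester, its branching carbon or the defined stereocentre. The compounds shown therefore leave open whether a plain methyl, an unbranched chain, the corresponding carboxylic acid or the opposite stereocentre on the same nitrogen would cost as much, less or more.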